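Chloro for methyl in a weakly active series

The source may hold more compounds than are shown below. What is called first, only, known or untested is meant among the compounds shown, and "the series" means these compounds.

Compound 1 `O=C(NNc1cccc(Cl)c1)c1ccc(NS(=O)(=O)c2cnc(O)nc2O)cc1`: 11600 nM
Compound 2 `O=C(NNc1ccc(F)cc1)c1ccc(NS(=O)(=O)c2cnc(O)nc2O)cc1`: > 20000 nM (a limit)
Compound 3 `Cc1cccc(NNC(=O)c2cccc(NS(=O)(=O)c3cnc(O)nc3O)c2)c1`: > 20000 nM (a limit)

In a functional assay on SGC-7901 cells (Homo sapiens) for antiproliferative activity, read by MTT assay, with a stated time of 24 h (on this read-out lower numbers stand for stronger inhibition and higher numbers for weaker inhibition), compound 3 gives only a limit and not a number, so it stands at the limit of > 20000 nM in this assay, at which 2 of the 3 values shown sit. Compound 4 `O=C(NNc1cccc(Cl)c1)c1cccc(NS(=O)(=O)c2cnc(O)nc2O)c1` differs from it by one change: chloro in place of methyl on an aromatic carbon. Among the measured compounds shown here, only one measured step bears on this, an at least 1.7-fold higher number from compound 1 to compound 2 (0.23 log units; that floor lies within the scatter), and it was made on a different core, so it offers weak guidance. Compound 1 carries the same 3-chlorophenyl and gives 11600 nM, so a modest move towards a lower number is expected. The expected step is an at least 1.1-fold lower number from compound 3 to compound 4 (0.04 log units; that floor lies within the scatter). Compound 4 is estimated at 18000 nM, with an expected range from 9000 nM to 35000 nM.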

Compound 4, half-maximal inhibitory concentration: 11800 nM
Compound 4: middle estimate off by 1.5-fold (0.18 log units), on the high side; measured number inside the range.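

In this assay, chloro in place of methyl on this aromatic carbon gives an at least 1.6-fold lower number from compound 3 to compound 4 (0.22 log units; that floor lies within the scatter). Compound 3 gives only a limit, so the true size of this step stays unknown: the limit of > 20000 nM in this assay, at which 2 of the 4 values shown sit.

Compound 4 gives 11800 nM and compound 1 gives 11600 nM; these values lie within the usual scatter of each other, so both compounds carrying 3-chlorophenyl give a number rather than a limit.

As far as these compounds go, whether bromo, trifluoromethyl or methoxy at this place would give a lower number remains open. So does whether a second chloro on the same ring would do so.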